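This account rests on a few compounds, and the source may have more. Where it says the series, first, only, none or still open, it means among the compounds named here.

Compound 1 `Cc1ccc(C(=O)N2CCN(CC(=O)N3CCN(CCCc4c[nH]c5ccccc45)CC3)CC2)cc1`: > 200000 nM (a limit)
Compound 2 `Cc1ccc(C(=O)N2CCN(CC(=O)N3CCN(CCCc4c[nH]c5ccc(F)cc45)CC3)CC2)cc1`: 119000 nM
Compound 3 `COc1ccc2[nH]cc(CCCN3CCN(C(=O)CN4CCN(C(=O)c5ccc(C)cc5)CC4)CC3)c2c1`: > 200000 nM (a limit)

All three compounds were tested in an ADME assay on SH-SY5Y cells (Homo sapiens) for cytotoxicity, read by MTT assay, with a stated time of 72 h; on this read-out higher numbers stand for weaker inhibition and lower numbers for stronger inhibition. Compound 3 stands at the limit of > 200000 nM in this assay, at which 2 of the 3 values shown sit, so its reading is a limit and not a number.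

Compound 4 `COc1ccc2[nH]cc(CCCN3CCN(C(=O)CN4CCN(C(=O)c5ccccc5Br)CC4)CC3)c2c1` has 2-bromophenyl in place of the 4-methylphenyl of compound 3, on a carbonyl carbon: 2-bromophenyl in place of 4-methylphenyl on a carbonyl carbon.

The measured steps all concern fluoro or methoxy at a different place: an at least 1.6-fold lower number from compound 1 to compound 2 (0.22 log units; that floor lies within the scatter), an at least 1.6-fold higher number from compound 2 to compound 3 (0.22 log units; that floor lies within the scatter) and a step that the two limits leave unreadable from compound 1 to compound 3. None of them changes the group on the carbonyl carbon, so they give no direct guide to its effect. No step beyond the scatter is therefore expected in this assay, in either direction. The expected change is an at least 1.1-fold lower number from compound 3 to compound 4 (0.04 log units; that floor lies within the scatter). Going by the values given here, compound 2, at 119000 nM, is the only guide to the lower end of the expected range. Another limit reading remains quite possible for compound 4. For compound 4 the estimate is 180000 nM, with an expected range of 80000 nM to 350000 nM.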

Compound 4, half-maximal inhibitory concentration: 111000 nM
Compound 4: middle estimate off by 1.6-fold (0.21 log units), on the high side, and the stated range covers the measured number.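

This is the first change shown on the carbonyl carbon, and in this assay it gives an at least 1.8-fold lower number from compound 3 to compound 4 (0.25 log units; that floor lies within the scatter). Compound 3 reads > 200000 nM, which is a limit and not a number. Compound 4 has a readable number, so a change at this place alone, with the methoxy group kept, can bring the reading off the limit that is still common in this small set: the limit of > 200000 nM in this assay, at which 2 of the 4 values shown sit.

The change alters both the substituent on the phenyl ring and where it sits, and the compounds shown do not separate the two, so 4-bromophenyl and 2-methylphenyl would be the telling groups. Also open, as far as these compounds go, is how a phenyl ring carrying an amine or a carboxylic acid would read at this place in this assay.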